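Chloro Added to the Fused Ring of Compound 1

This account rests on a few compounds, and the source may have more. Where it says the series, first, only, none or still open, it means among the compounds named here.

Compound 1 `O=S(=O)(c1ccc(-c2cnc(C3CC3)o2)cc1)N1CCCOc2ccccc21` gives 36 nM.
Compound 2 `O=S(=O)(c1ccc(-c2cnc(C3CC3)o2)cc1)N1CCOCc2ccccc21` gives 175 nM.
Compound 3 `O=S(=O)(c1ccc(-c2cnc(C3CC3)o2)cc1)N1CCCc2ccccc21` gives 47 nM.

Of the compounds shown here, three that share one core have been tested in a functional assay on SK-OV-3 cells (Homo sapiens) for antiproliferative activity, read by MTT assay, with a stated time of 72 h; on this read-out higher numbers stand for weaker inhibition and lower numbers for stronger inhibition. Compound 1 has the lowest number of the three. Compound 3 lies close to it, within the usual scatter of repeated measurements, so the two cannot be told apart on these data. Compound 2 stands beyond the scatter, with the higher number, and so shows weaker inhibition than compound 1.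

Compound 4 `O=S(=O)(c1ccc(-c2cnc(C3CC3)o2)cc1)N1CCCOc2ccc(Cl)cc21` is the next compound to be measured in this assay. It differs from compound 1 in one place: chloro in place of hydrogen on an aromatic carbon. For the measured compounds named here, none of the measured pairs shows a change of this kind, so there is no measured step of the same sort to lean on. The expectation is that the change leaves the number close to where compound 1 stands, with no step beyond the scatter in either direction.

Compound 4 is therefore estimated at 32 nM, within a range from 10 nM to 100 nM. The step this estimate means is expected to be a 1.1-fold lower number from compound 1 to compound 4 (0.05 log units; within the scatter).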

Compound 4, half-maximal inhibitory concentration: 19 nM
Compound 4: the middle estimate sits 1.7-fold (0.23 log units) above what was measured; the measured number falls inside the stated range.
By their numbers in this assay, from the lowest: compounds 4, 1 and 3 (each within the scatter of the next, the first and the last beyond it); then compound 2.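

All three earlier compounds carry only hydrogen on the aromatic carbon that is meta to a fused ring and para to a fused ring, so they could not show what a substituent there would do. In this assay, chloro in place of that hydrogen gives a 1.9-fold lower number from compound 1 to compound 4 (0.28 log units; within the scatter) and so shows that this position can carry a chlorine atom with no loss of inhibition, while a true gain cannot be claimed from a step of this size. Nothing measured here explains this result.

One chloro on one carbon says little about the position as a whole: a fluoro, a methoxy group, an amine or a carboxylic acid on this same carbon could give quite different numbers, and only such compounds would show how much room the position really offers. Also open, from the compounds shown here alone, is whether chloro would give a similar result on the other aromatic carbons of this ring, or at the matching place on the core of compound 3.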